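Tetrahydronaphthalenyl for cyclohexyl: expected cathepsin S binding

The compounds below may be only part of what the source reports. "The series", "measured", "known", "first", "only" and "open" are said of these compounds alone.

compound 1 `N#C[C@@]1(NC(=O)[C@@H](CC(=O)N2CCOCC2)CC2Cc3ccccc3C2)CCN(C2CCCCC2)C1` — 23.1 nM
compound 2 `N#C[C@@]1(NC(=O)[C@@H](CC(=O)N2CCOCC2)CC2CCCCC2)CCN(C2CCCCC2)C1` — 17.8 nM

In an assay on isolated protein for inhibition of cathepsin S (Homo sapiens) (on this read-out lower numbers stand for tighter binding and higher numbers for weaker binding), compound 1 gives 23.1 nM and compound 2 gives 17.8 nM. Compound 2 sits alongside compound 1, the step of a 1.3-fold lower number from compound 1 to compound 2 (0.11 log units; within the scatter) falling within the scatter. Compound 3 `N#C[C@@]1(NC(=O)[C@@H](CC(=O)N2CCOCC2)CC2CCc3ccccc3C2)CCN(C2CCCCC2)C1` differs from compound 2 by 1,2,3,4-tetrahydronaphthalen-2-yl in place of cyclohexyl on a saturated chain carbon, two bonds along the chain from a carbonyl carbon. Among the compounds with values here, the only measured step bearing on this, a 1.3-fold lower number from compound 1 to compound 2 (0.11 log units; within the scatter), exchanged 2,3-dihydro-1H-inden-2-yl for cyclohexyl without a shift beyond the scatter; the change to compound 3 reverses that with the related 1,2,3,4-tetrahydronaphthalen-2-yl. No step beyond the scatter is therefore expected in this assay. Compound 3 is expected to give 20 nM, range 8 nM to 50 nM. The expected step of a 1.1-fold higher number from compound 2 to compound 3 (0.05 log units; within the scatter) is estimated to lie within the scatter.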

Compound 3, dissociation constant: 5.4 nM
The estimate for compound 3 lay 3.7-fold (0.57 log units) above the measured number, outside the stated range (below it).
By their numbers in this assay, from the lowest: compound 3; then compounds 2 and 1 (each within the scatter of the next).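

At this saturated chain carbon, two bonds along the chain from a carbonyl carbon, this assay does respond to the group carried: 1,2,3,4-tetrahydronaphthalen-2-yl gives a 3.3-fold lower number from compound 2 to compound 3 (0.52 log units; beyond the scatter) against cyclohexyl and a 4.3-fold lower number from compound 1 to compound 3 (0.63 log units; beyond the scatter) against 2,3-dihydro-1H-inden-2-yl. Since those two replaced groups stay within the scatter of each other, the gain among these compounds is specific to 1,2,3,4-tetrahydronaphthalen-2-yl. No available measurement accounts for this gain. Open, on these data alone, is whether naphthalen-2-yl or 1,2,3,4-tetrahydronaphthalen-1-yl at this place would hold the gain.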